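A few compounds are considered here, and "the series" means these few. Any claim that something is new, unique, unknown or untested is made for them only; others in the source may bear on it.

Measured so far in an ADME assay on a cell-free system (serum, Homo sapiens) for pharmacokinetics, read by HPLC, tested at 200 uM; a higher number here means that the compound lasts longer, a lower number that the compound disappears faster:
compound 1 `O=C(CCOc1nonc1-c1ccccc1)Oc1ccccc1C(=O)O` — 0.667 h
compound 2 `N#Cc1nonc1CSCC(=O)Oc1ccccc1C(=O)O` — 0.233 h
compound 3 `N#Cc1c(CSCC(=O)Oc2ccccc2C(=O)O)no[n+]1[O-]` — 0.217 h

Compound 2 holds the second highest of the three half-life numbers. Its nearest neighbour is compound 3, whose number sits within the scatter of that of compound 2, so no order between the two is claimed. Compound 1 lies furthest from compound 2, with a clearly higher number that falls beyond the scatter; what separates compound 1 from the other two in structure is more than one change, so nothing is said of that gap beyond the two values.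

Compound 4 `NC(=O)c1nonc1CSCC(=O)Oc1ccccc1C(=O)O` has not yet been measured in this assay. It differs from compound 2 in one place: carbamoyl in place of cyano on an aromatic carbon. Among the compounds with values here, no pair that differs only in this way has been measured, so there is no step to lean on. On what the three numbers show, with compound 2 at 0.233 h and compound 3 close beside it, the half-life of compound 4 is expected to stay near that of compound 2, with at most a small rise and no step beyond the scatter.

The estimated half-life for compound 4 is 0.28 h, with a range from 0.15 h to 0.55 h. This estimate means a step of a 1.2-fold higher number from compound 2 to compound 4 (0.08 log units; within the scatter), expected to lie within the scatter.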

Compound 4, half-life in the serum assay: 0.45 h
For compound 4 the middle estimate is 1.6-fold (0.21 log units) below the measured one, and the stated range covers the measured number.
By their numbers in the serum assay, from the lowest: compounds 3, 2, 4 and 1 (each within the scatter of the next, the first and the last beyond it).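

Carbamoyl in place of cyano, on the aromatic carbon next to the ring nitrogen, now has its first one-place reading: in the serum assay the pair gives a 1.9-fold higher number from compound 2 to compound 4 (0.29 log units; within the scatter), so the new hydrogen-bond donor and the extra heavy atom at this position bring no step that can be told from the scatter, and no order between the two compounds is claimed. The same pair reads alike in a physicochemical assay for pharmacokinetics, read by HPLC, in phosphate buffer, at pH 7.4, tested at 100 uM (a higher number here means that the compound lasts longer, a lower number that the compound disappears faster), where compound 2 gives 0.633 h and compound 4 gives 0.833 h, with a 1.3-fold higher number from compound 2 to compound 4 (0.12 log units; within the scatter) as the step, so neither assay separates the two compounds. Nothing measured on these compounds offers a reason for either reading.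

Still open, going by these compounds, is whether another group at this place, such as a carboxylic acid, an amine or a longer chain, would give a step beyond the scatter in either assay. Within the data shown here, also open is whether carbamoyl in place of cyano reads the same way on the core of compound 3, since the only pair for this change sits on the core of compound 2.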